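Taking the acetyl off a compound at the assay limit

A few compounds are considered here, and "the series" means these few. Any claim that something is new, unique, unknown or untested is made for them only; others in the source may bear on it.

Compound 1 (`COc1ccc(C2=C(c3cc(OC)c(OC)c(OC)c3)C(=O)C(OC(C)=O)C2)cc1OC(C)C`) gives > 100 ug/mL as its result in an ADME assay on PA-1 cells (Homo sapiens) for cytotoxicity, read by MTT assay, with a stated time of 72 h (on this read-out lower numbers stand for stronger inhibition and higher numbers for weaker inhibition), and this is a limit and not a number. In this assay compound 2 (`COc1ccc(C2=C(c3cc(OC)c(OC)c(OC)c3)C(=O)C(OC(C)=O)C2)cc1F`) gives > 100 ug/mL as its result, again a limit. Compound 1 therefore stands at the limit of > 100 ug/mL in this assay, at which 2 of the 2 values shown sit, with no exact number to start from.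

Compound 3 (`COc1ccc(C2=C(c3cc(OC)c(OC)c(OC)c3)C(=O)C(O)C2)cc1OC(C)C`) changes one place of compound 1, acetoxy to hydroxy (hydrogen in place of acetyl on an oxygen on a saturated carbon), with hydrogen in place of acetyl on an oxygen on a saturated carbon. Among the compounds with values here, the only measured step is a step that the two limits leave unreadable from compound 1 to compound 2 with fluoro in place of isopropoxy on an aromatic carbon. That step concerns a different place and offers no size to carry over. The expectation in this assay is thus for no firm step beyond the scatter, and only a move towards stronger inhibition could appear as a real number. The estimated step is an at least 1.2-fold lower number from compound 1 to compound 3 (0.09 log units; that floor lies within the scatter) as a rough guide only. Compound 3 is estimated at 80 ug/mL with an expected range of 10 ug/mL to 200 ug/mL and a good chance of ending as a limit only.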

Compound 3, half-maximal inhibitory concentration: > 100 ug/mL
Compound 3: only a limit was reported; the forecaster's own chance of this, stated with the estimate: 55%; at least 1.2-fold (0.09 log units) between middle value and limit.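

In this assay compound 3 gives > 100 ug/mL as a limit and not a number. Compound 1 also ends as a limit, so no step between compound 1 and compound 3 can be read, and compound 1, compound 2 and compound 3 share one result: the limit of > 100 ug/mL in this assay, at which 3 of the 3 values shown sit.

Whether acetoxy to hydroxy changes inhibition at all stays open, since none of these compounds has an exact number.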